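A few compounds are considered here, and "the series" means these few. Any claim that something is new, unique, unknown or untested is made for them only; others in the source may bear on it.

Measured in a functional assay on the whole organism (strain Kunming) with Mus musculus as the target, in the formalin test, with a stated time of 0.5 h; on this read-out higher numbers stand for an effect only at larger amounts of compound and lower numbers for an effect already at smaller amounts:
- compound 1 `COc1cc(OC)c(OC)cc1/C=C/COC(=O)/C=C/c1ccc(OC)c(OC)c1`: 93.3 mg/kg
- compound 2 `COc1cc(OC)c(OC)cc1/C=C/COC(=O)/C=C/c1ccccc1Cl`: 101 mg/kg
- compound 3 `COc1ccc(/C=C/C(=O)OC/C=C/c2cc(OC)c(OC)cc2OC)cc1`: 122 mg/kg

Compound 1 lies within the usual scatter of both compound 2 and compound 3, so it is not separated from either. Compound 4 `COc1cc(OC)c(OC)cc1/C=C/COC(=O)/C=C/c1ccc(Cl)cc1` is still unmeasured. Its difference from compound 1 is 4-chlorophenyl in place of 3,4-dimethoxyphenyl on a double-bonded chain carbon bound to a double-bonded chain carbon. The measured step that also replaces 3,4-dimethoxyphenyl, here with 2-chlorophenyl, is a 1.1-fold higher number from compound 1 to compound 2 (0.03 log units; within the scatter). Hydrogen in place of methoxy gave a 1.3-fold higher number from compound 1 to compound 3 (0.12 log units; within the scatter), and the remaining step is a 1.2-fold higher number from compound 2 to compound 3 (0.08 log units; within the scatter). No step beyond the scatter is therefore expected in this assay. The expected step is a 1.1-fold higher number from compound 1 to compound 4 (0.05 log units; within the scatter). The estimated value for compound 4 is 105 mg/kg. The expected range for compound 4 runs from 60 mg/kg to 180 mg/kg.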

Compound 4, dose for half-maximal effect: 108 mg/kg
Beside the measured number, compound 4's estimate is 1.0-fold (0.01 log units) below it; the measured number falls inside the stated range.
By their numbers in this assay, from the lowest: compounds 1, 2, 4 and 3 (each within the scatter of the next).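

In this assay, 4-chlorophenyl in place of 3,4-dimethoxyphenyl (a 1.2-fold higher number from compound 1 to compound 4 (0.06 log units; within the scatter)) and in place of 2-chlorophenyl (a 1.1-fold higher number from compound 2 to compound 4 (0.03 log units; within the scatter)) leaves the number unseparated, so a chlorophenyl at this place shows no dependence on where the chloro stands. Chloro in place of methoxy (a 1.1-fold lower number from compound 3 to compound 4 (0.05 log units; within the scatter)) adds a direct exchange of these two groups on the aromatic carbon, also without separation. No supporting data bear on why the series stays this flat.

Open, on these data alone, is whether an amine or a carboxylic acid on this aromatic ring would give a step beyond the scatter. A non-aromatic group such as a longer alkyl chain at this place also remains untested by the compounds shown.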